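The source may hold more compounds than are shown below. What is called first, only, known or untested is meant among the compounds shown, and "the series" means these compounds.

Compound 1 `COc1ccc(F)cc1CNCCCNc1ccnc2cc(Cc3ccc(C#N)cc3)ccc12` stands lowest of the three compounds measured in a physicochemical assay for solubility, with a stated time of 18 h, at pH 7.4; a lower number here means a less soluble compound, a higher number a more soluble compound: compound 1 gives 4200 nM. Compound 2 `c1ccc(Oc2ccc3c(NCCCNCc4ccco4)ccnc3c2)cc1` gives 14500 nM in this assay, and compound 3 `Clc1ccc(Oc2ccc3c(NCCCNCc4ccco4)ccnc3c2)cc1` gives 14500 nM, so compound 1 is the least soluble of the three, its gap to each of the others being beyond the scatter. Within the data shown here, the only step measured between compounds that differ in one place, no change at the digits printed from compound 2 to compound 3 (within the scatter), belongs to a pair whose core compound 1 does not share, and it concerns a different kind of change.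

Compound 4 `COc1ccc(F)cc1CNCCCNc1ccnc2cc(CCC(C)C)ccc12` differs from compound 1 in one place: isobutyl in place of 4-cyanophenyl on a saturated chain carbon bound to an aromatic carbon. Among the measured compounds shown here, no measured step involves a change of this kind, so nothing among the three compounds fixes the size or direction of the step in this assay. Compound 4 is therefore expected to give 4000 nM, with a range from 1300 nM to 12000 nM. The step is expected to read a 1.1-fold lower number from compound 1 to compound 4 (0.02 log units; within the scatter), not clearly beyond the scatter.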

Compound 4, solubility: 4200 nM
For compound 4 the middle estimate is 1.1-fold (0.02 log units) below the measured one, within the range that was stated.
By their numbers in this assay, from the lowest: compounds 1 and 4 (each within the scatter of the next); then compounds 2 and 3 (each within the scatter of the next).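

Read in this assay, the exchange of 4-cyanophenyl for isobutyl on a saturated chain carbon bound to an aromatic carbon shows no change at the digits printed from compound 1 to compound 4 (within the scatter) and gives the first reading of any change at this position. On the core of compound 1, then, a six-membered aromatic ring carrying a nitrile and an open isobutyl chain without a ring read alike at this place, so neither the ring nor the nitrile is shown to be needed for the number seen here. No measured evidence bears on why the two groups read alike.

On these data alone, it stays open whether a group of another kind at this place, such as a primary amine, a carboxylic acid or a longer alkyl chain, would read differently. As far as these compounds go, whether the same exchange would read alike on another core also stays open.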